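The source may report more compounds than this note shows. Statements on the series, on what has been measured and on what is new or still open speak of the compounds shown alone.

Among the measured compounds shown here, in a functional assay on MCF-10A cells (Homo sapiens) for antiproliferative activity, with a stated time of 48 h (a lower number here means that less compound is needed, a higher number that more compound is needed for the effect), compound 1 (`COc1ccc2nc(C)cc(NCc3ccc(F)c(F)c3)c2c1`) gives 9100 nM and compound 2 (`Cc1cc(NCc2ccc(F)cc2)c2ccccc2n1`) gives 15400 nM, so compound 2 lies within the usual scatter of the only other measured compound. Compound 3 (`COc1ccc2c(NCc3ccc(F)cc3)cc(C)nc2c1`) has methoxy in place of hydrogen on an aromatic carbon of compound 2 (methoxy in place of hydrogen on an aromatic carbon). For the measured compounds named here, no measured pair shows this change alone. Compound 1 also carries methoxy and gives 9100 nM, so no step beyond the scatter is expected in this assay, in either direction. The expected step is a 1.3-fold lower number from compound 2 to compound 3 (0.11 log units; within the scatter). For compound 3 the estimated value is 12000 nM, with an expected range from 5000 nM to 30000 nM.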

Compound 3, half-maximal effective concentration: 10200 nM
Estimate against measurement, compound 3: 1.2-fold (0.07 log units) above, within the range that was stated.
By their numbers in this assay, from the lowest: compounds 1, 3 and 2 (each within the scatter of the next).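

Among the compounds shown here, the pair of compound 2 and compound 3 gives the first reading of this change alone: in this assay, methoxy in place of hydrogen on this aromatic carbon, meta to a fused ring and para to a fused ring, gives a 1.5-fold lower number from compound 2 to compound 3 (0.18 log units; within the scatter). At this place, then, the added group does not move the number beyond the scatter. Nothing measured on these compounds speaks to why the step has this size.

The compounds shown leave open whether a different group on this carbon, such as an amine, a carboxylic acid or a longer ether chain like butoxy, would give a step beyond the scatter.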